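Methoxy for methylsulfanyl on the benzyl group

The compounds below may be only part of what the source reports. "The series", "measured", "known", "first", "only" and "open" are said of these compounds alone.

Compound 2 `CSc1ccc(CNc2nc(SC)nc3ncccc23)cc1` holds the lowest of the two numbers reported. In a functional assay on HTB-54 cells (Homo sapiens) for cytotoxicity, read by MTT assay, with a stated time of 72 h (on this read-out higher numbers stand for weaker inhibition of growth and lower numbers for stronger inhibition of growth), compound 2 gives 3280 nM. Compound 1 `COc1ccc(CNc2nc([Se]C)nc3ccccc23)cc1` differs from it in more than one place at once; in this assay compound 1 gives 33000 nM, a higher number that lies beyond the scatter. Compound 3 `C[Se]c1nc([Se]C)c2cccnc2n1` has no result reported in this assay: for compound 3 the entry reads "not determined" (no result reported). Compound 4 `COc1ccc(CNc2nc(SC)nc3ncccc23)cc1` is the single-change partner of compound 2: methoxy in place of methylsulfanyl on an aromatic carbon. For the measured compounds named here, no pair of measured compounds isolates this change, and compound 1 carries the methoxy only together with other alterations, so it gives no clean guide. The step from compound 2 to compound 4 is expected to be a 1.8-fold higher number from compound 2 to compound 4 (0.26 log units; within the scatter), a weakening that may not clear the scatter. Compound 4 is estimated at 6000 nM, within 1500 nM to 25000 nM.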

Compound 4, concentration for 50% growth inhibition: > 100000 nM
Compound 4 was reported as a limit (the forecaster's own chance of this, stated with the estimate: 5%); middle value at least 16-fold (1.22 log units) away from the limit.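

In this assay, the exchange of sulfur for oxygen in this group on an aromatic carbon is not a neutral swap: methoxy in place of methylsulfanyl gives an at least 30-fold higher number from compound 2 to compound 4 (1.48 log units; beyond the scatter). For the compounds shown here, the position is thus sensitive to this change, which the earlier compounds could not show, as no measured pair isolated it. Compound 4 gives a limit, not a number, so the step has no upper bound: the limit of > 100000 nM in this assay, at which 1 of the 4 values shown sits.

Going by these compounds, whether the methylsulfanyl sulfur itself is what matters remains open. An amine or a longer alkylsulfanyl chain at this carbon would help to separate the possibilities.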